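Isopropyl in Place of Methyl at the Amide-Bearing Carbon

The source may hold more compounds than are shown below. What is called first, only, known or untested is meant among the compounds shown, and "the series" means these compounds.

Of the compounds shown here, three with a shared core have been measured so far. Compound 1 `O=C(CN(c1ncnc2c1ncn2C1CCCCO1)C1CC1)N[C@@H](CCC(=O)OCc1ccccc1)C(=O)OCc1ccccc1` gives 14.1% in a functional assay on the whole organism (Tail, strain ICR) with Mus musculus as the target, in the tail flick test, with a stated time of 150 min, at a dose of 25 umol/kg by the oral route; a lower number here means a weaker effect, a higher number a stronger effect of the compound at the dose given. Compound 2 `O=C(CN(c1ncnc2c1ncn2C1CCCCO1)C1CC1)NCC(=O)OCc1ccccc1` gives 7.26% in this assay, and compound 3 `C[C@H](NC(=O)CN(c1ncnc2c1ncn2C1CCCCO1)C1CC1)C(=O)OCc1ccccc1` gives 6.01%. The number for compound 3 is the lowest of the three, but a number 1.3 percentage points lower from compound 2 to compound 3 (within the scatter) and a number 8.1 percentage points lower from compound 1 to compound 3 (within the scatter) both lie within the scatter, so nothing separates compound 3 from the other two.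

Compound 4 `CC(C)[C@H](NC(=O)CN(c1ncnc2c1ncn2C1CCCCO1)C1CC1)C(=O)OCc1ccccc1` differs from compound 3 in one place: isopropyl in place of methyl on a saturated chain carbon bound to an amide-type nitrogen and a carbonyl carbon. Going by the values given here, the steps that bear on this change are those at the same saturated chain carbon bound to an amide-type nitrogen and a carbonyl carbon: a number 6.8 percentage points lower from compound 1 to compound 2 (within the scatter) and a number 1.3 percentage points lower from compound 2 to compound 3 (within the scatter). Both were within the scatter, as was a number 8.1 percentage points lower from compound 1 to compound 3 (within the scatter). Among the compounds with values here, nothing measured so far shows that changing the group at this carbon moves the read-out beyond the scatter, so no step beyond the scatter is expected in this assay in either direction. The step expected for compound 4 is a number 1.5 percentage points higher from compound 3 to compound 4 (within the scatter). For compound 4 the estimate is 7.5%, expected to fall between 1% and 16%.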

Compound 4, a percentage reported as activity, at one dose (the size of the read-out at that dose, not a potency): 21.1%
Compound 4: the middle estimate sits 13.6 percentage points below what was measured, outside the stated range (above it).
By their numbers in this assay, from the lowest: compounds 3, 2, 1 and 4 (each within the scatter of the next, the first and the last beyond it).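

Going by these compounds alone, at the saturated chain carbon bound to an amide-type nitrogen and a carbonyl carbon, a change of group now moves the read-out in this assay beyond the scatter for the first time, in modest steps, both for isopropyl in place of methyl (a number 15.1 percentage points higher from compound 3 to compound 4 (beyond the scatter)) and for isopropyl in place of hydrogen (a number 13.8 percentage points higher from compound 2 to compound 4 (beyond the scatter)). Isopropyl is not separated from 2-(benzyloxycarbonyl)ethyl (a number 7 percentage points higher from compound 1 to compound 4 (within the scatter)), and compound 1 also stays within the scatter of compound 2 and compound 3, so it neither joins compound 4 as a clear step up nor goes against it, and the gain is firm only for isopropyl against hydrogen and methyl. No evidence on hand bears on this result.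

The compounds shown leave open whether the branching of isopropyl matters at this carbon, since neither a straight propyl chain nor a tert-butyl or cyclohexyl group stands among them. They also leave open whether the step would survive with a free carboxylic acid in place of the benzyl ester.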